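The source may report more compounds than this note shows. Statements on the series, on what has been measured and on what is new or still open speak of the compounds shown alone.

Compound 1 `COc1ccc(C2N=C(SCc3ccccc3Cl)NC(C)=C2C(=O)Nc2ccc(F)cc2)cc1OC` gives 17% in a functional assay on the whole organism (artery, strain albino) with Rattus norvegicus as the target, with a stated time of 120 min, at a dose of 10 mg/kg by the oral route; a higher number here means more inhibition at the dose given (going by the name of the read-out), a lower number less inhibition. Among the compounds with values here, the only other measured compound, compound 2 `COc1ccc(C2N=C(SCc3ccc(F)cc3)NC(C)=C2C(=O)Nc2ccc(F)cc2)cc1OC`, gives 15.5% in this assay, and the step of a number 1.5 percentage points lower from compound 1 to compound 2 (within the scatter) lies within the scatter, so the two cannot be told apart. Compound 3 `CC1=C(C(=O)Nc2ccc(F)cc2)C(c2ccc([N+](=O)[O-])cc2)N=C(SCc2ccccc2Cl)N1` differs from compound 1 by 4-nitrophenyl in place of 3,4-dimethoxyphenyl on a saturated ring carbon. Within the data shown here, the one measured step swaps a group on a saturated chain carbon bound to a sulfur, a different part of the shared core, so no measured step bears on this change. The step of no change at the digits printed from compound 1 to compound 3 (within the scatter) is therefore expected to stay within the scatter, and compound 3 is expected to give about 17% in this assay, between 5% and 30%.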

Compound 3, a percentage reported as inhibition, in the whole organism at one dose (the size of the read-out at that dose, not a potency): 8.8%
Estimate against measurement, compound 3: 8.2 percentage points above; the range from low to high includes it.
By their numbers in this assay, from the lowest: compounds 3, 2 and 1 (each within the scatter of the next).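

Swapping in 4-nitrophenyl for 3,4-dimethoxyphenyl on the saturated ring carbon gives a number 8.2 percentage points lower from compound 1 to compound 3 (within the scatter) in this assay. At this one oral dose, the two aromatic groups therefore cannot be told apart, even though they carry different substituents. Nothing shown here offers an explanation for this result. On these data alone, it remains open whether a 4-aminophenyl group or a plain methyl group on this ring carbon would also stay within the scatter. Also open, as far as these compounds go, is whether these two groups would remain indistinguishable at another dose.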